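The source may hold more compounds than are shown below. What is called first, only, known or untested is meant among the compounds shown, and "the series" means these compounds.

Measured in a toxicity assay on HT-29 cells (Homo sapiens) for cytotoxicity; on this read-out higher numbers stand for lower toxicity in this test and lower numbers for higher toxicity in this test:
- compound 1 `CCCCCn1nc(C(=O)N[C@H]2COc3ccccc3N(C)C2=S)nc1Cc1ccccc1`: > 100000 nM, a limit
- compound 2 `CN1C(=S)[C@@H](NC(=O)c2nc(Cc3ccccc3)n(CCCC#N)n2)COc2ccccc21`: > 100000 nM, a limit
- compound 3 `CN1C(=S)[C@@H](NC(=O)c2nc(Cc3ccccc3)n(C3CCCC3)n2)COc2ccccc21`: > 100000 nM, a limit

Compound 3 has no exact number in this assay, only the limit > 100000 nM. It shares that position with both other compounds, as the record shows: the limit of > 100000 nM in this assay, at which 3 of the 3 values shown sit.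

Compound 4 `CN1C(=S)[C@@H](NC(=O)c2nc(Cc3ccccc3)n(C3CCCCC3)n2)COc2ccccc21` carries cyclohexyl in place of cyclopentyl on an aromatic nitrogen. Three measured steps change the group on this same nitrogen or its chain. The closest is a step that the two limits leave unreadable from compound 1 to compound 3, where cyclopentyl replaces pentyl. The others are a step that the two limits leave unreadable from compound 2 to compound 3 and a step that the two limits leave unreadable from compound 1 to compound 2. None of them has a readable size or direction, so none can be carried over to the new change as a number.

What they do show is that pentyl, 3-cyanopropyl and cyclopentyl on this nitrogen all end at the same limit. Compound 3 and its two neighbours therefore lead to the expectation of no step beyond the scatter in this assay, and another limit is the most likely report. The expected change is a number no higher from compound 3 to compound 4 (the limit leaves the size open). The estimate for compound 4 is 100000 nM, with an expected range from 40000 nM to 250000 nM.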

Compound 4, half-maximal cytotoxic concentration: > 100000 nM
Compound 4 ended at the assay's limit; the forecaster's own chance of this, stated with the estimate: 88%; the middle value sits exactly at the limit.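

In this assay compound 4 gives > 100000 nM, which is a limit. No step from compound 1, compound 2 or compound 3 to compound 4 can be read, as all four share one position: the limit of > 100000 nM in this assay, at which 4 of the 4 values shown sit.

The compounds shown leave open whether the group on the aromatic nitrogen changes this read-out at all, as none has an exact number.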